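The compounds below may be only part of what the source reports. "The series", "measured", "known", "first", "only" and "open" are said of these compounds alone.

Working notes on the series. The shared core carries a primary amine pair and a phenyl group; variation is confined to the arylmethylamine arm. Compound 1 `CCOC(=O)[C@H](CCC(=O)O)NC(=O)c1ccc(CNc2nc3cc(N)cc(N)c3nc2-c2ccccc2)cc1` gives 28200 nM in a functional assay on RPMI8266 cells (Homo sapiens) for inhibition, read by sulforhodamine B assay, with a stated time of 48 h; a higher number here means a weaker inhibitor of growth, a lower number a stronger inhibitor of growth. Compound 2 `Nc1cc(N)c2nc(-c3ccccc3)c(NCc3ccc(Cl)c(Cl)c3)nc2c1` gives 1660 nM in this assay. Compound 3 `COc1ccc(CNc2nc3cc(N)cc(N)c3nc2-c2ccccc2)cc1OC` gives 2140 nM in this assay, which places it second of the three numbers: the nearest step is a 1.3-fold higher number from compound 2 to compound 3 (0.11 log units; within the scatter), while compound 1 sits a good deal higher, well beyond the scatter.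

Compound 4 `COc1cc(CNc2nc3cc(N)cc(N)c3nc2-c2ccccc2)cc(OC)c1OC` has not been measured. It differs from compound 3 by methoxy in place of hydrogen on an aromatic carbon. Going by the values given here, no measured pair covers this exact change; the only step on the aryl ring, a 1.3-fold higher number from compound 2 to compound 3 (0.11 log units; within the scatter), exchanged one substituted ring for another without moving the number beyond the scatter. Adding a third methoxy is therefore expected to leave the number near that of compound 3, with an expected step of a 1.2-fold higher number from compound 3 to compound 4 (0.07 log units; within the scatter). Compound 4 is estimated at 2500 nM, within 900 nM to 7000 nM.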

Compound 4, concentration for 50% growth inhibition: 692 nM
Compound 4: the middle estimate sits 3.6-fold (0.56 log units) above what was measured, outside the stated range (below it).
By their numbers in this assay, from the lowest: compound 4; then compounds 2 and 3 (each within the scatter of the next); then compound 1.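

Methoxy in place of hydrogen on this aromatic carbon, ortho to a methoxy group and meta to a large group, brings a 3.1-fold lower number from compound 3 to compound 4 (0.49 log units; beyond the scatter) in this assay and so shifts the number by more than the scatter, which the exchange of ring substituents in a 1.3-fold higher number from compound 2 to compound 3 (0.11 log units; within the scatter) did not do. The aryl ring of the arm therefore does respond to substitution, although this single pair shows it only for a third methoxy added to the 3,4-dimethoxyphenyl ring. Nothing at hand accounts for the size of this step.

As far as these compounds go, whether the step belongs to methoxy itself stays open: a hydroxy, an ethoxy or an amine on the same carbon would test that. Also open, from the compounds shown here alone, is whether methoxy on this carbon has the same effect without the other two methoxy groups.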